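Biphenyl variation in the cinnamate amide series

The source may hold more compounds than are shown below. What is called first, only, known or untested is meant among the compounds shown, and "the series" means these compounds.

Measured compounds:
compound 1 `COC(=O)/C=C/c1cccc(N(Cc2ccc(/C=C/c3ccccc3)cc2)C(=O)C2CCCCC2)c1` — 36 nM
compound 2 `COC(=O)/C=C/c1cccc(N(Cc2ccc(-c3ccccc3OC)cc2)C(=O)C(C)C)c1` — 377 nM
compound 3 `Cc1cc(OCc2c(-c3c(Cl)cncc3Cl)noc2C(C)C)ccc1-c1ccc2c(c1)c(C(=O)O)cn2C` — 94 nM

In a functional assay for agonist activity at Bile acid receptor (Homo sapiens) (a higher number here means that more compound is needed for the effect, a lower number that less compound is needed), compound 2 gives 377 nM, the highest of the three numbers. The nearest is compound 3 at 94 nM, a gap beyond the scatter; the furthest is compound 1 at 36 nM, also beyond the scatter. For the measured compounds named here, compound 1 shares the cinnamate amide core with compound 2 but carries a different amide group and a different substituent on the benzyl ring, so no single-point step connects them.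

Compound 4 `COC(=O)/C=C/c1cccc(N(Cc2ccc(-c3ccc(C(C)(C)C)cc3)cc2)C(=O)C(C)C)c1` differs from compound 2 in one place: 4-(tert-butyl)phenyl in place of 2-methoxyphenyl on an aromatic carbon. Going by the values given here, no measured pair covers this change. Since compound 1, which also carries an extended substituent para to a large group, gives 36 nM, the number for compound 4 is expected to move downward, by a step of moderate size that may exceed the scatter. Compound 4 is estimated at 120 nM, within 35 nM to 400 nM, an expected step of a 3.1-fold lower number from compound 2 to compound 4 (0.50 log units; beyond the scatter).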

Compound 4, half-maximal effective concentration: 343 nM
Beside the measured number, compound 4's estimate is 2.9-fold (0.46 log units) below it, within the range that was stated.
By their numbers in this assay, from the lowest: compound 1; then compound 3; then compounds 4 and 2 (each within the scatter of the next).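

In this assay, for the compounds shown here, 4-(tert-butyl)phenyl in place of 2-methoxyphenyl on this aromatic carbon gives a 1.1-fold lower number from compound 2 to compound 4 (0.04 log units; within the scatter), the only single-place step so far. At this position, with the amide group held constant, an all-carbon aryl group of 10 heavy atoms with no hydrogen-bond acceptor and an aryl group of 8 heavy atoms with 1 hydrogen-bond acceptor stay within the scatter of each other. No available evidence bears on the reason for this result.

The step alters the substituent and its place on the ring together, so 4-methoxyphenyl or 2-(tert-butyl)phenyl would be needed to read the two separately. Also open, on these data alone, are whether an aryl group bearing a carboxylic acid or an amine stays within the scatter here, and whether the result holds with a cyclohexanecarbonyl amide.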